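The source may report more compounds than this note shows. Statements on the series, on what has been measured and on what is new or still open speak of the compounds shown alone.

Compounds measured in a functional assay on CHO-K1 cells for antagonist activity at transient receptor potential cation channel subfamily V member 1 (Homo sapiens), read by FLIPR; on this read-out lower numbers stand for stronger inhibition and higher numbers for weaker inhibition:
compound 1 `CC(C(=O)NCc1ccc(C(F)(F)F)nc1NCC1CCN(C(=O)OC(C)(C)C)CC1)c1ccc(NS(C)(=O)=O)c(F)c1` gives 1140 nM
compound 2 `CCCN(CCC)c1nc(C(F)(F)F)ccc1CNC(=O)C(C)c1ccc(NS(C)(=O)=O)c(F)c1` gives 14.7 nM
compound 3 `CC(C(=O)NCc1ccc(C(F)(F)F)nc1N(C)c1ccccc1)c1ccc(NS(C)(=O)=O)c(F)c1` gives 57.4 nM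

Compound 3 stands second highest of the three numbers; its nearest neighbour is compound 2, its furthest compound 1. Among the measured compounds shown here, the one single-point step recorded runs a 3.9-fold higher number from compound 2 to compound 3 (0.59 log units; beyond the scatter), so exchanging one amino substituent for another on this aromatic carbon has shifted the read-out modestly.

Compound 4 `CC(C(=O)NCc1ccc(C(F)(F)F)nc1N1CCC(O)CC1)c1ccc(NS(C)(=O)=O)c(F)c1` carries 4-hydroxypiperidin-1-yl in place of methyl(phenyl)amino on an aromatic carbon. For the measured compounds named here, no measured step covers this exchange; the step from compound 2 to compound 3 shows only that substitution at this position matters modestly, while compound 1 and compound 2 show that the spread across amino groups can be wide. For compound 4 a step of a 1.6-fold higher number from compound 3 to compound 4 (0.20 log units; within the scatter) is therefore expected, within the scatter. Compound 4 is estimated at 90 nM, in a range of 25 nM to 350 nM.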

Compound 4, half-maximal inhibitory concentration: "not active" (no number reported)
No number was reported for compound 4, and the estimate cannot be compared.
By their numbers in this assay, from the lowest: compound 2; then compound 3; then compound 1.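

Among the compounds shown here, compound 4 is recorded only as "not active", without a number, so no step from compound 3 to compound 4 can be read. The compounds shown leave open how 4-hydroxypiperidin-1-yl compares numerically with methyl(phenyl)amino. No evidence bears on this result.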